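Cyclopropyl to cyclobutyl on the piperazine amide

This account rests on a few compounds, and the source may have more. Where it says the series, first, only, none or still open, it means among the compounds named here.

Of the compounds shown here, three sharing one core have been tested in a functional assay on CHO-K1 cells for antagonist activity at melanin-concentrating hormone receptor 1 (Homo sapiens), read by inositol phosphate accumulation; on this read-out higher numbers stand for weaker inhibition and lower numbers for stronger inhibition. Compound 1 `Cc1nc(N2CCN(S(C)(=O)=O)CC2)nc2ccc(NC(=O)COc3ccc(Cl)cc3)cc12` gives only a limit of the assay, > 10000 nM. Compound 2 `Cc1nc(N2CCC(NC(=O)C(C)C)CC2)nc2ccc(NC(=O)COc3ccc(Cl)cc3)cc12` gives 54 nM, and compound 3 `Cc1nc(N2CCN(C(=O)C3CC3)CC2)nc2ccc(NC(=O)COc3ccc(OC(F)(F)F)cc3)cc12` gives 30 nM, a number that sits close to that of compound 2, within the scatter of repeated measurements. Compound 4 `Cc1nc(N2CCN(C(=O)C3CCC3)CC2)nc2ccc(NC(=O)COc3ccc(OC(F)(F)F)cc3)cc12` differs from compound 3 in one place: cyclobutyl in place of cyclopropyl on a carbonyl carbon. Among the measured compounds shown here, no measured pair shows what such a change does here. The expectation for compound 4 is a number near that of compound 3, with the step from compound 3 to compound 4 estimated as a 1.1-fold higher number from compound 3 to compound 4 (0.03 log units; within the scatter), not beyond the scatter. Compound 4 is expected at 32 nM, within 12 nM to 85 nM.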

Compound 4, half-maximal inhibitory concentration in the melanin-concentrating hormone receptor 1 assay: 45 nM
The estimate for compound 4 lay 1.4-fold (0.15 log units) below the measured number; low and high end bracket the measured number.
By their numbers in the melanin-concentrating hormone receptor 1 assay, from the lowest: compounds 3, 4 and 2 (each within the scatter of the next). At a limit, above all of these: compound 1.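

In the melanin-concentrating hormone receptor 1 assay compound 3 gives 30 nM and compound 4 gives 45 nM. Among the compounds shown here, in the melanin-concentrating hormone receptor 1 assay the swap gives a 1.5-fold higher number from compound 3 to compound 4 (0.18 log units; within the scatter), so on this carbonyl carbon cyclobutyl and cyclopropyl cannot be told apart, a point the earlier compounds could not settle. In a physicochemical assay for solubility, in phosphate buffer (a higher number here means a more soluble compound, a lower number a less soluble compound), compound 3 gives 8000 nM and compound 4 gives 4000 nM. In the physicochemical assay the same swap gives a 2.0-fold lower number from compound 3 to compound 4 (0.30 log units; within the scatter), so the two rings cannot be told apart there either. Nothing shown bears on why the two rings read so alike.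

From the compounds shown here alone, whether the position would accept a still larger ring such as cyclopentyl stays open. So does what an amine or a carboxylic acid on the cyclobutyl ring would do in either assay.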